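The source may hold more compounds than are shown below. What is called first, only, known or untested is meant among the compounds shown, and "the series" means these compounds.

In a functional assay on K562 cells (Homo sapiens) for inhibition, read by fluorescence, with a stated time of 72 h (on this read-out higher numbers stand for weaker inhibition of growth and lower numbers for stronger inhibition of growth), two compounds have been measured so far. Compound 1 (`CC(C)CCn1cnc2c(NCc3cccc(Cl)c3)nc(N[C@H]3CC[C@H](N)CC3)nc21`) gives 3100 nM in the test, and compound 2 (`CCCCCCn1cnc2c(Nc3cccc(Cl)c3)nc(N[C@H]3CC[C@H](N)CC3)nc21`) gives 2300 nM there. These two numbers lie within the scatter of each other, so compound 2 stands level with compound 1 on the data available. Compound 3 (`CC(C)CCn1cnc2c(Nc3cccc(Cl)c3)nc(N[C@H]3CC[C@H](N)CC3)nc21`) has not yet been measured. It differs from compound 2 only in its chain: isopropyl in place of butyl on a saturated chain carbon, two bonds along the chain from an aromatic nitrogen, which, cut one bond further out, reads hexyl to isopentyl. Within the data shown here, no measured pair shows this change alone. Compound 1 carries the isopentyl chain as well, although it differs from compound 3 elsewhere, and compound 1 gives 3100 nM in the same test. On that basis, no step beyond the scatter is expected in this assay in either direction. The expected change is a 1.1-fold higher number from compound 2 to compound 3 (0.04 log units; within the scatter) and this estimate stays within the scatter. The estimated value for compound 3 is 2500 nM with an expected range from 1100 nM to 5500 nM on repeated measurement.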

Compound 3, concentration for 50% growth inhibition: 1500 nM
Compound 3: middle estimate off by 1.7-fold (0.22 log units), on the high side; the range from low to high includes it.
By their numbers in this assay, from the lowest: compounds 3, 2 and 1 (each within the scatter of the next, the first and the last beyond it).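

In this assay, among these compounds, the first pair that differs in one place at the chain shows that isopropyl in place of butyl on a saturated chain carbon, two bonds along the chain from an aromatic nitrogen, also read as hexyl to isopentyl, gives a 1.5-fold lower number from compound 2 to compound 3 (0.19 log units; within the scatter), so the two chains stand level at this position on this read-out. The second pair keeps the isopentyl chain and isolates a different place: 3-chlorophenyl in place of 3-chlorobenzyl on a nitrogen on an aromatic ring gives a 2.1-fold lower number from compound 1 to compound 3 (0.32 log units; beyond the scatter), a modest step and the only one here that lies beyond the scatter. No measurement at hand accounts for either step.

The compounds shown leave open whether the step from 3-chlorobenzyl to 3-chlorophenyl would carry over to the hexyl chain, as it is seen only with the isopentyl chain. They also leave open what a cyclopentyl ring, or a chain ending in a hydroxyl group or a carboxylic acid, would give at the chain position, and what a 2-phenylethyl group would give on that nitrogen.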